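Benzyl-triazole ethers on the shared core: notes toward compound 4

The source may hold more compounds than are shown below. What is called first, only, known or untested is meant among the compounds shown, and "the series" means these compounds.

Compound 1 `COc1cc(Cn2cc(COc3cccc(/C=C4/C(=O)Nc5ccccc54)c3)nn2)cc(OC)c1` in a functional assay on BT-549 cells (Homo sapiens) for inhibition, read by MTT assay, with a stated time of 48 h (on this read-out lower numbers stand for stronger inhibition and higher numbers for weaker inhibition), stands as "not determined" (no result reported).
Compound 2 `O=C1Nc2cc(Cl)ccc2/C1=C\c1cccc(OCc2cn(Cc3ccccc3)nn2)c1` in this assay gives only a limit, > 50000 nM.
Compound 3 `O=C1Nc2ccc(F)cc2/C1=C\c1cccc(OCc2cn(Cc3ccccc3)nn2)c1` in this assay likewise gives only a limit, > 50000 nM.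

Where compound 3 stands is therefore only a limit of the assay, not a number; the series so far holds no single measured value at all, and the two compounds that were run both sit at the limit of > 50000 nM in this assay, at which 2 of the 3 values shown sit. Going by the values given here, no step between measured compounds can be computed, so the halogen variation across compound 2 and compound 3 tells only that both stay at the limit.

The next member, compound 4 `COc1ccc(Cc2ccc3c(c2)/C(=C\c2cccc(OCc4cn(Cc5ccccc5)nn4)c2)C(=O)N3)cc1`, carries 4-methoxybenzyl in place of fluoro on an aromatic carbon, that is, 4-methoxybenzyl in place of fluoro on an aromatic carbon, meta to a fused ring and para to a fused ring. Among the compounds with values here, the change is a large one in size compared with the single fluorine it replaces, and there is no measured pair to say how the shared core answers to substitution of this kind.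

The expectation is a step toward lower numbers for compound 4, of size an at least 3.3-fold lower number from compound 3 to compound 4 (0.52 log units; beyond the scatter), though with the real possibility that the read-out again stops at the limit. Compound 4 is thus estimated at 15000 nM, within a range from 2000 nM to 60000 nM.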

Compound 4, half-maximal inhibitory concentration: > 50000 nM
Compound 4: only a limit was reported (the forecaster's own chance of this, stated with the estimate: 50%); middle value at least 3.3-fold (0.52 log units) away from the limit.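

In this assay, compound 3 and compound 4 each give only a limit, so no step can be read between them and the exchange of fluoro for 4-methoxybenzyl has no readable size: the limit of > 50000 nM in this assay, at which 3 of the 4 values shown sit.

What the compounds shown leave open is whether any substitution on the shared core gives a single measured number rather than a limit.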